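Compound 1 without its trifluoromethyl group

A few compounds are considered here, and "the series" means these few. Any claim that something is new, unique, unknown or untested is made for them only; others in the source may bear on it.

In an ADME assay on the whole organism (Mus musculus, strain ICR) for pharmacokinetics, read by HPLC, with a stated time of 24 h, at a dose of 50 mg/kg by the oral route (a lower number here means less compound in the circulation, a higher number more compound in the circulation at the dose given), compound 1 (`CCc1nc2ccc(Br)cn2c1C(=O)NCCOc1ccc(N2CCC(C(F)(F)F)CC2)cc1`) gives 9420 nM, within the scatter of compound 2 (`CCc1nc2ccc(Cl)cn2c1C(=O)NCCOc1ccc(N2CCN(c3ccc(F)cc3)CC2)cc1`) at 6380 nM. Compound 3 (`COc1ccc2nc(C)c(C(=O)NCCOc3ccc(N4CCC(C(F)(F)F)CC4)cc3)n2c1`) gives 1340 nM, lower than compound 1 by more than the scatter. Compound 4 (`CCc1nc2ccc(Br)cn2c1C(=O)NCCOc1ccc(N2CCCCC2)cc1`) has hydrogen in place of trifluoromethyl on a saturated ring carbon. Among the measured compounds shown here, no measured pair isolates this change. Compound 2 lacks the trifluoromethyl group and still reaches 6380 nM, while compound 3 carries it and gives only 1340 nM, so the two offer no support for a large step. A modest fall is expected, estimated as a 2.4-fold lower number from compound 1 to compound 4 (0.37 log units; beyond the scatter). For compound 4 the estimate is 4000 nM, with an expected range of 1300 nM to 12000 nM.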

Compound 4, maximal plasma concentration: 2090 nM
Compound 4: middle estimate off by 1.9-fold (0.28 log units), on the high side, and the stated range covers the measured number.
By their numbers in this assay, from the lowest: compounds 3 and 4 (each within the scatter of the next); then compounds 2 and 1 (each within the scatter of the next).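

With the rest of compound 1 held fixed, the change from 4-(trifluoromethyl)piperidin-1-yl to piperidin-1-yl gives in this assay a 4.5-fold lower number from compound 1 to compound 4 (0.65 log units; beyond the scatter). Among the compounds shown here, this is the first reading of this change alone, which the earlier compounds, differing in several places at once, could not give, and it shows that the substituent on this saturated ring carbon matters to maximal plasma concentration. No measurement at hand accounts for the step.

Still open, from the compounds shown here alone, is whether a methyl group, a single fluorine or a hydroxyl group on the same ring carbon keeps the higher number. Going by these compounds, whether the step carries over to other cores is also open.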